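A few compounds are considered here, and "the series" means these few. Any claim that something is new, unique, unknown or untested is made for them only; others in the source may bear on it.

Two compounds of a shared core carrying a ((2-(4-methylpiperazin-1-yl)ethyl)amino)methyl group have been measured in an ADME assay on Huh-7 cells (Homo sapiens) for cytotoxicity; on this read-out higher numbers stand for lower toxicity in this test and lower numbers for higher toxicity in this test. Compound 1 `CN1CCN(CCNCc2cn(-c3ccc([N+](=O)[O-])cc3)nc2-c2ccc(OC(F)(F)F)cc2)CC1` gives 4400 nM. Compound 2 `Cc1ccccc1-c1nn(-c2cccc(C(F)(F)F)c2)cc1CNCCN1CCN(C)CC1` gives 18000 nM, the higher of the two numbers, and the gap down to compound 1 lies beyond the usual scatter of this assay, so compound 2 is the less toxic of the pair in this test.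

Compound 3 `Cc1ccccc1-c1nn(-c2ccc([N+](=O)[O-])cc2)cc1CNCCN1CCN(C)CC1` has not yet been measured. It differs from compound 2 in one place: 4-nitrophenyl in place of 3-(trifluoromethyl)phenyl on an aromatic nitrogen. For the measured compounds named here, no pair of measured compounds isolates this single change, so its effect is not known. Compound 1 also carries a 4-nitrophenyl group and shows the lower number, but it differs from compound 3 in a second place as well, so its value is only a loose hint.

Compound 3 is expected to move modestly toward higher toxicity, by about a 2.0-fold lower number from compound 2 to compound 3 (0.30 log units; within the scatter). Compound 3 is estimated at 9000 nM, within a range from 3000 nM to 27000 nM.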

Compound 3, half-maximal cytotoxic concentration: > 20000 nM
Compound 3 gave a limit, no number (the forecaster's own chance of this, stated with the estimate: 10%); middle value at least 2.2-fold (0.34 log units) from the limit.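

In this assay compound 3 gives > 20000 nM, which is a limit of the assay and not a number. On these data alone, on the aromatic nitrogen, 4-nitrophenyl in place of 3-(trifluoromethyl)phenyl gives an at least 1.1-fold higher number from compound 2 to compound 3 (0.04 log units; that floor lies within the scatter), so this swap shows no sign of added toxicity, though the floor alone cannot establish a real gain and the true size of the step stays unknown. With 4-nitrophenyl now held constant on that nitrogen, 2-methylphenyl in place of 4-(trifluoromethoxy)phenyl on the aromatic carbon gives an at least 4.5-fold higher number from compound 1 to compound 3 (0.65 log units; beyond the scatter), which isolates a change that compound 1 and compound 2 could not separate, since they differ in two places, and ties a clear drop in toxicity in this test to the group on the carbon.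

As far as these compounds go, whether the 4-(trifluoromethoxy)phenyl group lowers the number in the same way with 3-(trifluoromethyl)phenyl on the nitrogen remains open. So does the outcome of other groups on that nitrogen, such as an unsubstituted phenyl or a cyclohexyl ring, or of a morpholine in place of the 4-methylpiperazine at the end of the side chain.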